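Benzamido swap on the amide-type nitrogen: series notes

The source may hold more compounds than are shown below. What is called first, only, known or untested is meant among the compounds shown, and "the series" means these compounds.

In a functional assay on MCF7 cells (Homo sapiens) for antiproliferative activity, read by MTT assay (on this read-out higher numbers stand for weaker inhibition and lower numbers for stronger inhibition), compound 1 `COc1cc2c(Oc3ccc(NC(=O)Nc4cccc(C)c4)cc3)ccnc2cc1OCCCCCCC(=O)NO` gives 1240 nM and compound 2 `COc1cc2c(Oc3ccc(NC(=O)N/N=C/c4ccc(F)cc4)cc3)ccnc2cc1OCCCCCCC(=O)NO` gives 1360 nM. Among the compounds with values here, compound 2 therefore stands level with compound 1, the only other measured compound, within the scatter. Compound 3 `COc1cc2c(Oc3ccc(NC(=O)NNC(=O)c4ccccc4)cc3)ccnc2cc1OCCCCCCC(=O)NO` has not yet been measured. Its change from compound 2 is a group of 9 heavy atoms (7 carbon, 1 nitrogen, 1 oxygen; one six-membered aromatic ring of carbon only) in place of a group of 9 heavy atoms (7 carbon, 1 nitrogen, 1 fluorine; one six-membered aromatic ring of carbon only), on an amide-type nitrogen, with benzamido entering on an amide-type nitrogen whose other neighbours are: carbonyl carbon. Within the data shown here, one measured step bears on this: a 1.1-fold higher number from compound 1 to compound 2 (0.04 log units; within the scatter), a change on an amide-type nitrogen that stayed within the scatter. Among the measured compounds shown here, no measured compound carries benzamido, so the data indicate no direction, and no change beyond the scatter is expected in this assay. The estimated step is a 1.1-fold higher number from compound 2 to compound 3 (0.04 log units; within the scatter). For compound 3 the expected value is 1500 nM, with an estimated range of 600 nM to 4000 nM.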

Compound 3, half-maximal inhibitory concentration: 2450 nM
Compound 3: the middle estimate sits 1.6-fold (0.21 log units) below what was measured; the range from low to high includes it.
By their numbers in this assay, from the lowest: compounds 1, 2 and 3 (each within the scatter of the next).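

On the amide-type nitrogen, benzamido, with 1 hydrogen-bond donor where the group it replaces has 0, gives a 1.8-fold higher number from compound 2 to compound 3 (0.26 log units; within the scatter) in this assay, and in place of 3-methylphenyl it gives a 2.0-fold higher number from compound 1 to compound 3 (0.30 log units; within the scatter). All three groups on this nitrogen, each holding a six-membered aromatic ring of carbon only, therefore stay within the scatter of one another, including across this difference in hydrogen-bond donors. No supporting data are available to explain these steps.

As far as these compounds go, whether a group without an aromatic ring on this nitrogen, such as a short alkyl chain or an amine, or a carboxylic acid on the benzamido ring, would give a step beyond the scatter remains open. Also open, from the compounds shown here alone, is whether these groups stay level when the chain on the shared core is shorter or longer.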